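The source may hold more compounds than are shown below. What is called first, only, known or untested is meant among the compounds shown, and "the series" means these compounds.

Measured compounds:
compound 1 `Oc1ccc(CNc2cc(C(F)(F)F)cc3[nH]ncc23)cc1`: 91%
compound 2 `Oc1ccc(CNc2cc(C(F)(F)F)cc3[nH]ncc23)c(Cl)c1`: 97%
compound 3 `FC(F)(F)c1cc(NCc2cccc3sccc23)c2cn[nH]c2c1`: 5%

In an assay for inhibition of Tryptophan 2,3-dioxygenase (Homo sapiens), with stated times of 10 min and 60 min, tested at 100 uM (a higher number here means a stronger effect of the compound at the concentration tested, a lower number a weaker effect), compound 1 gives 91%, the second highest of the three numbers. Its nearest neighbour is compound 2, where the change a number 6 percentage points higher from compound 1 to compound 2 (within the scatter) is within the scatter, so no order between these two can be read. Going by the values given here, compound 3 stands far lower with 5%; no single step is computed for that pair, but the two values show that exchanging the group on the chain carbon can remove almost all of the effect.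

Compound 4 `FC(F)(F)c1cc(NC[C@@H]2CCCCN2)c2cn[nH]c2c1` differs from compound 1 as follows: piperidin-2-yl in place of 4-hydroxyphenyl on a saturated chain carbon bound to a nitrogen on an aromatic ring. Among the compounds with values here, the only measured step, from compound 1 to compound 2, concerns a different part of the molecule and is small, so it bears little on this change. The drop seen in compound 3 shows the group at this position matters, but the direction for a saturated ring is not fixed by the data. Compound 4 is therefore expected to land around 45%, between 5% and 90%, an estimated step of a number 46 percentage points lower from compound 1 to compound 4 (beyond the scatter).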

Compound 4, a percentage reported as inhibition, at one concentration (the size of the read-out at that concentration, not a potency): 88%
The estimate for compound 4 lay 43 percentage points below the measured number; measured number inside the range.
By their numbers in this assay, from the lowest: compound 3; then compounds 4, 1 and 2 (each within the scatter of the next).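

In this assay, putting piperidin-2-yl in place of 4-hydroxyphenyl gives a number 3 percentage points lower from compound 1 to compound 4 (within the scatter), so an aromatic ring of carbon only is not needed on the chain carbon for this read-out. Compound 3 with 5% had shown that a change here can remove almost all of the effect, whereas compound 4 shows that a very different group, a non-aromatic ring holding a nitrogen, can leave the read-out in the range of compound 1. Nothing at hand explains why these two exchanges end so differently.

The compounds shown leave open whether the opposite stereoisomer of piperidin-2-yl would give a similar read-out. They also leave open whether an open-chain amine or a carboxylic acid on the chain carbon would do the same.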